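This account rests on a few compounds, and the source may have more. Where it says the series, first, only, none or still open, it means among the compounds named here.

Measured so far in a functional assay for inhibition of sodium/hydrogen exchanger (Oryctolagus cuniculus); on this read-out higher numbers stand for weaker inhibition and lower numbers for stronger inhibition:
compound 1 `COc1ccc(C(=O)N=C(N)N)cc1S(C)(=O)=O`: 270 nM
compound 2 `CS(=O)(=O)c1cc(C(=O)N=C(N)N)ccc1N1CCCCC1`: 130 nM

Going by the values given here, compound 2 holds the lower of the two numbers in this assay, and the only measured step is a 2.1-fold lower number from compound 1 to compound 2 (0.32 log units; beyond the scatter), a modest one. Compound 3 `CS(=O)(=O)c1cc(C(=O)N=C(N)N)ccc1-n1ccc(=O)cc1` differs from compound 2 by a group of 7 heavy atoms (5 carbon, 1 nitrogen, 1 oxygen; one six-membered aromatic ring with 1 hetero atom) in place of a group of 6 heavy atoms (5 carbon, 1 nitrogen; one six-membered non-aromatic ring with 1 hetero atom), on an aromatic carbon. Among the compounds with values here, no measured step concerns an exchange of this kind; the single known step swaps methoxy for piperidin-1-yl and says nothing about the aromatic ring that enters here. A step of uncertain direction is therefore expected, set at a 2.3-fold higher number from compound 2 to compound 3 (0.36 log units; beyond the scatter) toward a somewhat higher number. Compound 3 is estimated at 300 nM, with a range of 80 nM to 1200 nM.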

Compound 3, half-maximal inhibitory concentration: 710 nM
Compound 3: middle estimate off by 2.4-fold (0.37 log units), on the low side; low and high end bracket the measured number.
By their numbers in this assay, from the lowest: compound 2; then compound 1; then compound 3.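

In this assay the position ortho to a methylsulfonyl group now shows that a substituent change here can also raise the number: the six-membered aromatic ring with 1 hetero atom gives a 5.5-fold higher number from compound 2 to compound 3 (0.74 log units; beyond the scatter) and a 2.6-fold higher number from compound 1 to compound 3 (0.42 log units; beyond the scatter) in turn. A six-membered ring with 1 hetero atom on this carbon therefore does not by itself keep the number low. The data give no reason for the rise.

Open, going by these compounds, is whether the ring's aromatic character or its carbonyl goes with the rise. Phenyl and piperidin-4-one at this position would separate the two.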